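The compounds below may be only part of what the source reports. "The series", "measured", "known", "first", "only" and "open" are said of these compounds alone.

Compound 1, `Cc1nc(SCC(=O)Nc2nc(-c3ccc(Cl)cc3)cs2)n(Nc2ccccc2)c1C`: in a functional assay on NCI-H522 cells (Homo sapiens) for antiproliferative activity, read by sulforhodamine B assay, with a stated time of 48 h (a lower number here means that less compound is tolerated, a higher number that more compound is tolerated), compound 1 gives 66500 nM.
Compound 2, `Cc1ccc(Nn2c(SCC(=O)Nc3nc(-c4ccccc4)cs3)nc(C)c2C)cc1`: in this assay compound 2 reaches a limit of the assay, > 100000 nM, not a number.

For the measured compounds named here, compound 1 is therefore the only compound with a measured number here; the other value is the limit of > 100000 nM in this assay, at which 1 of the 2 values shown sits. Going by the values given here, compound 1 and compound 2 differ in two places at once, so no single step between them can be read; their two values show only that compound 1 tolerates less compound than the limit reached by compound 2.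

Compound 3, `COc1ccc(Nn2c(SCC(=O)Nc3nc(-c4ccc(Cl)cc4)cs3)nc(C)c2C)cc1`, arises from compound 1 by methoxy in place of hydrogen on an aromatic carbon. Among the compounds with values here, no measured step exists for this change. The step from compound 1 to compound 3 is expected to be small, a 1.2-fold higher number from compound 1 to compound 3 (0.08 log units; within the scatter), slightly toward more compound tolerated, and may not exceed the scatter. Compound 3 is thus estimated at 80000 nM, within a range of 30000 nM to 200000 nM, with a real chance that only a limit is reported.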

Compound 3, concentration lethal to 50% of the cells: > 100000 nM
Compound 3 gave a limit, no number; the forecaster's own chance of this, stated with the estimate: 45%; middle value at least 1.2-fold (0.09 log units) from the limit.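

In this assay compound 3 gives > 100000 nM, which is a limit of the assay and not a number. Methoxy in place of hydrogen on this aromatic ring, which turns anilino into (4-methoxyphenyl)amino, can therefore be read only as an at least 1.5-fold higher number from compound 1 to compound 3 (0.17 log units; that floor lies within the scatter), so the change shows no sign of a lower number, but this floor does not establish a real rise. The true size of the step stays unknown, and limits now make up most of the picture: the limit of > 100000 nM in this assay, at which 2 of the 3 values shown sit.

From the compounds shown here alone, whether an amine or a carboxylic acid at this position would move the number in either direction remains open. Compound 1 is still the only compound with a measured number, so no change shown here gives a lower number than compound 1.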